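The compounds below may be only part of what the source reports. "The series", "measured", "known", "first", "only" and "open" are said of these compounds alone.

Measured compounds:
compound 1 `CCOC(=O)c1sc2ccc(NCc3c[nH]cn3)cc2c1NC(=O)c1ccccc1` — 17900 nM
compound 2 `CCOC(=O)c1sc2ccc(NCc3c[nH]cn3)cc2c1NC(=O)c1ccc(C)cc1` — 11700 nM

Compound 1 is the weaker of the two measured compounds on the numbers shown: in a functional assay on HeLa cells (Homo sapiens) for antiproliferative activity, read by MTT assay, with a stated time of 48 h (on this read-out lower numbers stand for stronger inhibition of growth and higher numbers for weaker inhibition of growth), compound 1 gives 17900 nM, the highest of the two values, and its only neighbour is compound 2 with 11700 nM. Among the measured compounds shown here, the single measured step, a 1.5-fold lower number from compound 1 to compound 2 (0.18 log units; within the scatter), adds a methyl in place of hydrogen on an aromatic carbon and does not move the number beyond the usual scatter.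

Compound 3 `CCOC(=O)c1sc2ccc(NCc3nc[nH]c3C)cc2c1NC(=O)c1ccccc1` is not yet measured. It differs from compound 1 by methyl in place of hydrogen on an aromatic carbon. For the measured compounds named here, this is again a methyl replacing a hydrogen on an aromatic carbon, though on a different part of the molecule than in compound 2, so the step from compound 1 to compound 2 is the only measured step that bears on it, and that step stayed within the scatter. Nothing measured here points to a change beyond the scatter in this assay. The expected step is a 1.2-fold lower number from compound 1 to compound 3 (0.08 log units; within the scatter). Compound 3 is therefore estimated at 15000 nM, with a likely range from 5000 nM to 45000 nM.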

Compound 3, concentration for 50% growth inhibition: 23300 nM
For compound 3 the middle estimate is 1.6-fold (0.19 log units) below the measured one; measured number inside the range.
By their numbers in this assay, from the lowest: compounds 2, 1 and 3 (each within the scatter of the next).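

In this assay the change from 1H-imidazol-4-yl to 5-methyl-1H-imidazol-4-yl gives a 1.3-fold higher number from compound 1 to compound 3 (0.11 log units; within the scatter) and so leaves the number indistinguishable from that of compound 1. Compound 2 had shown only that a methyl on a different part of the molecule gives a 1.5-fold lower number from compound 1 to compound 2 (0.18 log units; within the scatter) and now the five-membered aromatic ring, on a carbon next to the ring nitrogen, shows the same outcome for this one small group. Nothing measured here gives a reason for this result, and a step this small carries no sign of whether this carbon matters for growth inhibition. 

Going by these compounds, what stays open is whether a larger or different group on this ring carbon, such as an ethyl chain, an aminomethyl group or a carboxylic acid, would produce a step beyond the scatter in this assay and in which direction. Also open, on these data alone, is whether a methyl at this place and a methyl on the other part of the molecule would together move the number, since each has so far been seen only alone.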